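Thiophene isomer swap on the shared core

This account rests on a few compounds, and the source may have more. Where it says the series, first, only, none or still open, it means among the compounds named here.

Measured so far, in a functional assay on HCT-15 cells (Homo sapiens) for inhibition, read by sulforhodamine B assay, with a stated time of 48 h, tested at 10 uM; a lower number here means less inhibition, a higher number more inhibition at the concentration tested (going by the name of the read-out):
- compound 1 `c1ccc(-c2cn3ccnc3c(-c3ccc4ncn(C5CCCCC5)c4c3)n2)cc1` gives 51.6%
- compound 2 `O=Cc1ccc(-c2cn3ccnc3c(-c3ccc4ncn(C5CCCCC5)c4c3)n2)cc1` gives 49.1%
- compound 3 `c1cn2cc(-c3ccsc3)nc(-c3ccc4ncn(C5CCCCC5)c4c3)c2n1` gives 1.37%

Compound 3 stands lowest of the three numbers in this assay; its nearest neighbour is compound 2 and its furthest is compound 1, both far above it. The formyl step a number 2.5 percentage points lower from compound 1 to compound 2 (within the scatter) changes little. The two steps that replace the phenyl-type group by thiophen-3-yl are large: a number 50.2 percentage points lower from compound 1 to compound 3 (beyond the scatter) and a number 47.7 percentage points lower from compound 2 to compound 3 (beyond the scatter).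

Compound 4 `c1csc(-c2cn3ccnc3c(-c3ccc4ncn(C5CCCCC5)c4c3)n2)c1` differs from compound 3 in one place: thiophen-2-yl in place of thiophen-3-yl on an aromatic carbon. For the measured compounds named here, no measured step exchanges one thiophene isomer for the other, so the only numbers bearing on this change are the two large downward steps into compound 3 and the flat formyl step. They show that the thiophen-3-yl compound sits well below both phenyl compounds, but say nothing direct about thiophen-2-yl. The expectation for compound 4 is therefore a small upward step from compound 3, a number 13.6 percentage points higher from compound 3 to compound 4 (beyond the scatter), with wide uncertainty toward the phenyl level. Compound 4 is estimated at 15%, within the range 0% to 50%.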

Compound 4, a percentage reported as inhibition, at one concentration (the size of the read-out at that concentration, not a potency): 2.33%
Estimate against measurement, compound 4: 12.7 percentage points above; low and high end bracket the measured number.
By their numbers in this assay, from the lowest: compounds 3 and 4 (each within the scatter of the next); then compounds 2 and 1 (each within the scatter of the next).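

The exchange of thiophen-3-yl for thiophen-2-yl at this position is a flat change in this assay, a number 1 percentage points higher from compound 3 to compound 4 (within the scatter), so the low level of compound 3 is not tied to one thiophene isomer. Compound 4 lies as clearly under the phenyl-type compounds, with a number 49.3 percentage points lower from compound 1 to compound 4 (beyond the scatter) and a number 46.8 percentage points lower from compound 2 to compound 4 (beyond the scatter), and all four compounds now divide into a thiophene pair and a phenyl pair, with none going against that division. Nothing measured gives a reason for the gap between the two pairs.

On these data alone, it remains open whether the higher level belongs to the phenyl ring as such, which a pyridinyl group at the same position could test, and whether a formyl group on either thiophene would shift the low level of the pair. The flat formyl step also rests on a single substituent, so a carboxylic acid or an aminomethyl group on the phenyl ring might or might not hold the level of compound 1.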